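A Weak Starting Point and a Diethylamino Replacement

The compounds below may be only part of what the source reports. "The series", "measured", "known", "first", "only" and "open" are said of these compounds alone.

Of the compounds shown here, three of this small series have been tested in a functional assay on Jurkat cells (Homo sapiens) for cytotoxicity, read by MTT assay, with a stated time of 48 h; a higher number here means a weaker inhibitor, a lower number a stronger inhibitor. Compound 1 `CCN(CC)c1ccc(C(F)(F)F)cc1NC(=O)c1cccnc1` is reported as "not active" (no number reported). Compound 3 `O=C(Nc1cc(C(F)(F)F)ccc1NC1CCCCC1)c1ccccc1` is reported in this assay as "not active" (no number reported). Only compound 2 `O=C(Nc1cc(C(F)(F)F)ccc1NC1CCCCC1)c1ccncc1` gives a number: in this assay compound 2 reaches 80900 nM, which makes it the one entry of the three with a measured value, and a weak one at that.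

Compound 4 `CCN(CC)c1ccc(C(F)(F)F)cc1NC(=O)c1ccncc1` has not yet been measured. It differs from compound 2 in a single place: diethylamino in place of cyclohexylamino on an aromatic carbon. Among the compounds with values here, no pair of measured compounds shows this exchange on its own, so the size of the step cannot be read from the data. What can be set beside it is compound 1, which carries the same diethylamino group with a different amide and is reported as "not active" (no number reported).

On that basis the step from compound 2 to compound 4 is expected to run toward a weaker inhibitor, roughly a 2.0-fold higher number from compound 2 to compound 4 (0.30 log units; within the scatter), and a report of no number at all is a real possibility. For compound 4 the expected value in this assay is 160000 nM, with a range from 60000 nM to 450000 nM.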

Compound 4, half-maximal inhibitory concentration: "not active" (no number reported)
The entry for compound 4 holds no number; the estimate stays without a comparison.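

Within the data shown here, compound 4 is reported without a number in this assay, while compound 2 gives 80900 nM there, so no step from compound 2 to compound 4 can be read. The compounds shown leave open how far diethylamino in place of cyclohexylamino shifts the result, with compound 2 the only entry holding a number. No measured property bears on this outcome.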